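The compounds below may be only part of what the source reports. "The series", "measured", "known", "first", "only" and "open" are said of these compounds alone.

Compound 1 `ClCc1ccccc1Cn1cnc2ncnc(Cl)c21`: 4260 nM
Compound 2 `ClCc1cccc(Cn2cnc3nc(Cl)nc(Cl)c32)c1`: 3310 nM
Compound 3 `Nc1nc(Cl)c2ncn(Cc3cccc(CCl)c3)c2n1`: 4890 nM

In a functional assay on HCC 2998 cells (Homo sapiens) for cytotoxicity, read by sulforhodamine B assay, with a stated time of 48 h (on this read-out lower numbers stand for stronger inhibition of growth and higher numbers for weaker inhibition of growth), compound 1 gives 4260 nM, the second highest of the three numbers. Its nearest neighbour is compound 3 at 4890 nM and its furthest is compound 2 at 3310 nM; both gaps lie within the scatter, so these three compounds cannot be told apart on the numbers in hand. Compound 4 `ClCc1ccccc1Cn1cnc2nc(Cl)nc(Cl)c21` has not yet been measured. It differs from compound 1 in one place: chloro in place of hydrogen on an aromatic carbon. Among the compounds with values here, no measured pair shows this change on its own, and the three measured values all sit close together, so no direction can be read from them. The step is therefore expected to be small, a 1.2-fold lower number from compound 1 to compound 4 (0.07 log units; within the scatter), none beyond the scatter. Compound 4 is estimated at 3600 nM, with a range from 1500 nM to 8500 nM.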

Compound 4, concentration for total growth inhibition: 35500 nM
Compound 4: middle estimate off by 9.9-fold (0.99 log units), on the low side; measured number outside the range, above it.
By their numbers in this assay, from the lowest: compounds 2, 1 and 3 (each within the scatter of the next); then compound 4.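

Putting a chloro group on the aromatic carbon between two ring nitrogen atoms is not a silent change: in this assay it brings an 8.3-fold higher number from compound 1 to compound 4 (0.92 log units; beyond the scatter), which means weaker inhibition of growth. The earlier compounds shown here offered no single-change view of this step, and this pair shows that the position responds to substitution. Nothing available here accounts for the size of this step. As far as these compounds go, whether a fluoro, methyl or methoxy group on this carbon would bring a similar step stays open. So does whether chloro here would act the same way with other changes elsewhere in the molecule.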